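This account rests on a few compounds, and the source may have more. Where it says the series, first, only, none or still open, it means among the compounds named here.

Measured so far:
compound 1, `CN(C)CCn1cnnc1-c1cc(Oc2ccc(NC(=O)N/N=C/c3cccc(Br)c3)cc2F)ccn1`, 4230 nM in an ADME assay on WI-38 cells (Homo sapiens) for cytotoxicity, read by MTT assay, with a stated time of 72 h; on this read-out lower numbers stand for stronger inhibition and higher numbers for weaker inhibition
compound 2, `CN(C)CCn1cnnc1-c1cc(Oc2ccc(NC(=O)N/N=C/c3cc(Br)c(O)c(Br)c3)cc2F)ccn1`, "not determined" (no result reported) in this assay

In this assay compound 1 gives 4230 nM. In this assay compound 2 is reported as "not determined" (no result reported), so there is no number to set beside compound 1 and nothing can be said about where compound 2 stands. Compound 3 `COc1ccc(/C=N/NC(=O)Nc2ccc(Oc3ccnc(-c4nncn4CCN(C)C)c3)c(F)c2)c(OC)c1` is not yet measured and differs from compound 2 in one place: 2,4-dimethoxyphenyl in place of 3,5-dibromo-4-hydroxyphenyl on a carbon with a double bond to nitrogen. Within the data shown here, no step between measured compounds is available, so the size of the move from compound 2 to compound 3 in this assay cannot be read from the numbers at hand; the only anchor is compound 1, which shares the core and gives 4230 nM. A shift beyond the usual scatter, in either direction, cannot be supported. Compound 3 is therefore expected to land near that anchor, estimated at 5000 nM, with a range from 1500 nM to 20000 nM.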

Compound 3, half-maximal inhibitory concentration: 6630 nM
The estimate for compound 3 lay 1.3-fold (0.12 log units) below the measured number; measured number inside the range.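

In this assay putting 2,4-dimethoxyphenyl in place of 3-bromophenyl on a carbon with a double bond to nitrogen gives a 1.6-fold higher number from compound 1 to compound 3 (0.20 log units; within the scatter) and so stays within the usual scatter of repeated measurements. Among these compounds, this is the first comparison available at this position, and it shows that two differently decorated phenyl rings, one carrying a bromine and the other two methoxy groups, cannot be told apart on this read-out. No measurement shown here offers an explanation for this result.

The step from compound 2 to compound 3 cannot be read, since compound 2 has no number to compare. From the compounds shown here alone, whether an amine or a carboxylic acid on the phenyl ring, or a pyridine ring in place of that phenyl, would move the number beyond the scatter stays open.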